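Amide aryl swap: nitrophenyl in place of chloropyridinyl

A few compounds are considered here, and "the series" means these few. Any claim that something is new, unique, unknown or untested is made for them only; others in the source may bear on it.

Measured compounds:
compound 1 `CCn1cc(C(=O)Nc2ccccc2)c(=O)c2cc(F)c(N3CCNC(C)C3)c(F)c21`: 4400 nM
compound 2 `CCn1cc(C(=O)Nc2ccc(Cl)cn2)c(=O)c2cc(F)c(N3CCNC(C)C3)c(F)c21`: 1600 nM

In a functional assay on KB cells (Homo sapiens) for cytotoxicity, read by MTT assay (on this read-out higher numbers stand for weaker inhibition and lower numbers for stronger inhibition), compound 2 gives the lowest of the two numbers shown, the only comparison being compound 1. Compound 3 `CCn1cc(C(=O)Nc2cccc([N+](=O)[O-])c2)c(=O)c2cc(F)c(N3CCNC(C)C3)c(F)c21` differs from compound 2 by 3-nitrophenyl in place of 5-chloropyridin-2-yl on an amide-type nitrogen. Going by the values given here, the one measured step, a 2.8-fold lower number from compound 1 to compound 2 (0.44 log units; beyond the scatter), concerns the same amide aryl position; compound 3 returns to an all-carbon ring like compound 1, so a partial reversal is expected in this assay. The step of a 1.9-fold higher number from compound 2 to compound 3 (0.27 log units; within the scatter) is therefore expected. Compound 3 is estimated at 3000 nM, range 1200 nM to 8000 nM.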

Compound 3, half-maximal inhibitory concentration: 1700 nM
Estimate against measurement, compound 3: 1.8-fold (0.25 log units) above; measured number inside the range.
By their numbers in this assay, from the lowest: compounds 2 and 3 (each within the scatter of the next); then compound 1.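

In this assay the change gives a 1.1-fold higher number from compound 2 to compound 3 (0.03 log units; within the scatter), so 3-nitrophenyl and 5-chloropyridin-2-yl on the amide-type nitrogen cannot be told apart here. Nitro in place of hydrogen gives a 2.6-fold lower number from compound 1 to compound 3 (0.41 log units; beyond the scatter), which shows that a ring of carbon only can reach the level of compound 2 without a hetero atom in the ring. No measurement shown accounts for this result. Going by these compounds, it remains open whether an amine or a carboxylic acid in place of the nitro group would hold this level.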